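Cyano for nitro in the bis-benzylidene piperidinone series

The source may report more compounds than this note shows. Statements on the series, on what has been measured and on what is new or still open speak of the compounds shown alone.

Compound 1 `CC(=O)Nc1ccc(S(=O)(=O)N2C/C(=C\c3cccc([N+](=O)[O-])c3)C(=O)/C(=C/c3ccccc3F)C2)cc1` sets the baseline: in a functional assay on QGY-7703 cells (Homo sapiens) for cytotoxicity, read by MTT assay, with a stated time of 24 h (on this read-out higher numbers stand for weaker inhibition and lower numbers for stronger inhibition), compound 1 gives 7850 nM. Compound 2 `CC(=O)Nc1ccc(S(=O)(=O)N2C/C(=C\c3ccc(C#N)cc3)C(=O)/C(=C/c3ccccc3F)C2)cc1` carries 4-cyanophenyl in place of 3-nitrophenyl on a double-bonded chain carbon bound to a double-bonded ring carbon and in this assay compound 2 gives 2050 nM, a step of a 3.8-fold lower number from compound 1 to compound 2 (0.58 log units; beyond the scatter). Compound 3 `COc1cc(/C=C2\CN(S(=O)(=O)c3ccc(NC(C)=O)cc3)C/C(=C\c3cccc([N+](=O)[O-])c3)C2=O)cc(OC)c1OC` differs from compound 1 by 3,4,5-trimethoxyphenyl in place of 2-fluorophenyl on a double-bonded chain carbon bound to a double-bonded ring carbon; in this assay compound 3 gives 2550 nM, a step of a 3.1-fold lower number from compound 1 to compound 3 (0.49 log units; beyond the scatter). Compound 4 `COc1cc(/C=C2\CN(S(=O)(=O)c3ccc(NC(C)=O)cc3)C/C(=C\c3ccc(C#N)cc3)C2=O)cc(OC)c1OC` has not been measured. It differs from compound 3 by 4-cyanophenyl in place of 3-nitrophenyl on a double-bonded chain carbon bound to a double-bonded ring carbon, the same change as that from compound 1 to compound 2, at the same place; the two cores differ by 3,4,5-trimethoxyphenyl in place of 2-fluorophenyl on a double-bonded chain carbon bound to a double-bonded ring carbon. Among the compounds with values here, the expected step is a 3.0-fold lower number from compound 3 to compound 4 (0.48 log units; beyond the scatter), resting on the single precedent a 3.8-fold lower number from compound 1 to compound 2 (0.58 log units; beyond the scatter) and kept a little smaller since only one pair supports it. Compound 4 is expected at 850 nM, with a likely range from 400 nM to 2000 nM.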

Compound 4, half-maximal inhibitory concentration: 1890 nM
Compound 4: middle estimate off by 2.2-fold (0.35 log units), on the low side; the measured number falls inside the stated range.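

Carried onto the core of compound 3, the swap of 4-cyanophenyl for 3-nitrophenyl gives only a 1.3-fold lower number from compound 3 to compound 4 (0.13 log units; within the scatter) in this assay, so the step does not transfer at its earlier size: the same change on two cores in this assay, a 3.8-fold lower number (0.58 log units; beyond the scatter) from compound 1 to compound 2 and a 1.3-fold lower number (0.13 log units; within the scatter) from compound 3 to compound 4, 2.8-fold (0.45 log units) apart, beyond the scatter of two such steps. Read the other way, 3,4,5-trimethoxyphenyl in place of 2-fluorophenyl gives a 1.1-fold lower number from compound 2 to compound 4 (0.04 log units; within the scatter) on the 4-cyanophenyl core, so the two changes do not add: the same change on two cores in this assay, a 3.1-fold lower number (0.49 log units; beyond the scatter) from compound 1 to compound 3 and a 1.1-fold lower number (0.04 log units; within the scatter) from compound 2 to compound 4, 2.8-fold (0.45 log units) apart, beyond the scatter of two such steps. This rests on a single set of four compounds in one assay, and it does not show why the steps differ or how the swap behaves on any other core.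

Still open, as far as these compounds go, is whether a phenyl ring carrying an amine or a carboxylic acid, in place of 4-cyanophenyl, would follow the same non-additive pattern. Also open, from the compounds shown here alone, is whether the pattern holds on a core with a pyridine ring in place of 2-fluorophenyl.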